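From Fluoro to Chloro on the Aromatic Carbon

A few compounds are considered here, and "the series" means these few. Any claim that something is new, unique, unknown or untested is made for them only; others in the source may bear on it.

Three compounds share one core and differ only in a single substituent on an aromatic carbon. Compound 1 `Cc1cccc2c1CC/C2=C\C(=O)NC1CC1` carries a methyl there and in a functional assay on the whole organism with Mus musculus as the target (on this read-out lower numbers stand for an effect already at smaller amounts and higher numbers for an effect only at larger amounts of compound), gives 40 mg/kg. Compound 2 `O=C(/C=C1\CCc2ccccc21)NC1CC1` carries hydrogen and gives 150 mg/kg, while compound 3 `O=C(/C=C1\CCc2c(F)cccc21)NC1CC1` carries fluoro and gives 126 mg/kg. Compound 3 therefore stands second highest of the three numbers: its nearest neighbour is compound 2, within the scatter, and its furthest is compound 1. The steps of a 3.8-fold higher number from compound 1 to compound 2 (0.57 log units; beyond the scatter) and a 3.2-fold higher number from compound 1 to compound 3 (0.50 log units; beyond the scatter) are both modest and beyond the scatter, whereas the step of a 1.2-fold lower number from compound 2 to compound 3 (0.08 log units; within the scatter) lies within it.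

Compound 4 `O=C(/C=C1\CCc2c(Cl)cccc21)NC1CC1` has not yet been measured. It differs from compound 3 in one place: chloro in place of fluoro on an aromatic carbon. Among the compounds with values here, no measured step exchanges one halogen for another, so the bearing of the known steps is indirect: the methyl compound 1 gives the lowest number, and the hydrogen and fluoro compounds give numbers within the scatter of each other. On this basis compound 4 is expected to give a number between those of compound 3 and compound 1 in this assay. For compound 4 the expected step is a 1.4-fold lower number from compound 3 to compound 4 (0.15 log units; within the scatter). Compound 4 is estimated at 90 mg/kg, with a range from 40 mg/kg to 200 mg/kg.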

Compound 4, dose for half-maximal effect: 58 mg/kg
Compound 4: the middle estimate sits 1.6-fold (0.19 log units) above what was measured; the range from low to high includes it.
By their numbers in this assay, from the lowest: compounds 1 and 4 (each within the scatter of the next); then compounds 3 and 2 (each within the scatter of the next).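

In this assay, within the data shown here, this position on the aromatic carbon distinguishes one halogen from the other: chloro in place of fluoro gives a 2.2-fold lower number from compound 3 to compound 4 (0.34 log units; beyond the scatter) and is the first exchange of one halogen for another, whereas fluoro in place of hydrogen had left the number within the scatter. Chloro in place of hydrogen gives a 2.6-fold lower number from compound 2 to compound 4 (0.41 log units; beyond the scatter) and so shows that methyl is not the only group here that separates a compound from the unsubstituted one, while chloro in place of methyl gives a 1.5-fold higher number from compound 1 to compound 4 (0.16 log units; within the scatter) and places the two groups in no order on this read-out. There is no evidence to explain why chloro and methyl fall together here while fluoro stays with hydrogen.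

The compounds shown do not tell whether a larger halogen such as bromo, or groups such as methoxy, trifluoromethyl or an amine, would at this same place read with chloro and methyl or with fluoro and hydrogen. They also leave open whether chloro in place of fluoro would give a similar step on another aromatic carbon of the shared core.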